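The source may hold more compounds than are shown below. What is called first, only, known or untested is meant among the compounds shown, and "the series" means these compounds.

Working notes on the series. The shared core carries one variable group on an aromatic carbon: compound 1 `CC(C)CSc1nc(N)nc2c1ncn2/C=C1/CC1(CO)CO` has isobutylsulfanyl there, compound 2 `Nc1nc(NCc2ccccc2)c2ncn(/C=C3/CC3(CO)CO)c2n1` benzylamino, compound 3 `CCCCCOc1nc(N)nc2c1ncn2/C=C1/CC1(CO)CO` pentyloxy. In an ADME assay on CCRF-HSB-2 cells (Homo sapiens) for cytotoxicity, with a stated time of 7 days (a higher number here means that more compound is tolerated, a lower number that less compound is tolerated), compound 1 gives 60000 nM. For compound 2 the assay returns only a limit, > 20000 nM. Compound 3 likewise stands at a limit, > 20000 nM, so no number for it is known. Two of the three values sit at the limit of > 20000 nM in this assay, at which 2 of the 3 values shown sit, which leaves every step unreadable: a step that the limit leaves unreadable from compound 1 to compound 2, a step that the limit leaves unreadable from compound 1 to compound 3 and a step that the two limits leave unreadable from compound 2 to compound 3 all have no readable size. The next compound, compound 4 `CCCSc1nc(N)nc2c1ncn2/C=C1/CC1(CO)CO`, arises from compound 3 by propylsulfanyl in place of pentyloxy on an aromatic carbon. Within the data shown here, its propylsulfanyl group is close to the isobutylsulfanyl of compound 1, and compound 1 with 60000 nM supplies the only number in the set. Among the measured compounds shown here, with no measured step readable, the expectation rests on that single value. Compound 4 is expected to give 40000 nM, with a range from 15000 nM to 120000 nM. The estimated step that the limit leaves unreadable from compound 3 to compound 4 cannot be set against a number, as only a limit is known for its starting point. The measurement may itself return as a limit.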

Compound 4, half-maximal cytotoxic concentration: 98000 nM
The estimate for compound 4 lay 2.5-fold (0.39 log units) below the measured number, and the stated range covers the measured number.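

Among these compounds, with compound 4, this position on the aromatic carbon now carries two sulfanyl chains with real numbers in this assay, so a change within the chain can be read for the first time. Hydrogen in place of methyl on a saturated chain carbon bound to two saturated chain carbons gives a 1.6-fold higher number from compound 1 to compound 4 (0.21 log units; within the scatter), which means that propylsulfanyl and isobutylsulfanyl cannot be told apart here. The steps linking compound 4 or compound 1 to compound 2 and compound 3, and the step between those two, all remain unreadable because of the limit: the limit of > 20000 nM in this assay, at which 2 of the 4 values shown sit.

The compounds shown therefore do not tell whether the atom joining the chain to the aromatic carbon matters, as propylsulfanyl and pentyloxy differ in both that atom and chain length, and a pentylsulfanyl group would pair directly with the pentyloxy of compound 3. Going by these compounds, how far the tolerated concentration holds across the sulfanyl chains also stays open, since a methylsulfanyl group or a longer chain such as hexylsulfanyl lies outside the two closely related chains compared here.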